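This account rests on a few compounds, and the source may have more. Where it says the series, first, only, none or still open, it means among the compounds named here.

Measured compounds in a functional assay on T47D cells (Homo sapiens) for inhibition, read by sulforhodamine B assay, with a stated time of 48 h; a higher number here means a weaker inhibitor of growth, a lower number a stronger inhibitor of growth:
compound 1 `CC(=O)OC/C(=C\C1CCCCC1)C(=O)c1ccccc1`: 22000 nM
compound 2 `CCC(/C=C(\COC(C)=O)C(=O)c1ccccc1)CC`: 89000 nM
compound 3 `O=C(OC/C(=C\C1CCCCC1)C(=O)c1ccccc1)c1ccccc1`: 20000 nM

Compound 3 carries the lowest of the three numbers, but the nearest, compound 1, is not separated from it (a 1.1-fold lower number from compound 1 to compound 3 (0.04 log units; within the scatter)); only compound 2 stands apart, with a number higher than compound 1 by a 4.0-fold higher number from compound 1 to compound 2 (0.61 log units; beyond the scatter).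

Compound 4 `O=C(OC/C(=C\c1ccccc1[N+](=O)[O-])C(=O)c1ccccc1)c1ccccc1` is not yet measured. It differs from compound 3 in one place: 2-nitrophenyl in place of cyclohexyl on a double-bonded chain carbon bound to a double-bonded chain carbon. For the measured compounds named here, the only measured step at this place is the one from compound 1 to compound 2, where pentan-3-yl replaced cyclohexyl and the number rose modestly, beyond the scatter. Going by the values given here, no measured step puts an aromatic group at this place, so the direction for compound 4 is uncertain; the single precedent shows that this place is sensitive enough to move the number beyond the scatter, and a change of that order in either direction is expected. The estimate for compound 4 is 15000 nM, with a range from 3000 nM to 70000 nM, an expected step of a 1.3-fold lower number from compound 3 to compound 4 (0.12 log units; within the scatter).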

Compound 4, concentration for 50% growth inhibition: 16000 nM
The estimate for compound 4 lay 1.1-fold (0.03 log units) below the measured number; measured number inside the range.
By their numbers in this assay, from the lowest: compounds 4, 3 and 1 (each within the scatter of the next); then compound 2.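

In this assay, the place on a double-bonded chain carbon bound to a double-bonded chain carbon accepts an aromatic ring as well as a saturated one: 2-nitrophenyl for cyclohexyl gives a 1.3-fold lower number from compound 3 to compound 4 (0.10 log units; within the scatter). The sensitivity seen earlier, a 4.0-fold higher number from compound 1 to compound 2 (0.61 log units; beyond the scatter), therefore does not extend to every change at this place, although that step was read on the acetate ester and the new one on the benzoate ester. No measurement on hand bears on why this larger group with its hydrogen-bond acceptors leaves the number within the scatter.

The compounds shown leave open whether the nitro group contributes anything, since an unsubstituted phenyl or an amine-bearing phenyl at this place would separate it from the ring itself. They also leave open whether pentan-3-yl has the same effect on the benzoate ester.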